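A Smaller Amine Ring on the Sulfonyl Sulfur

The compounds below may be only part of what the source reports. "The series", "measured", "known", "first", "only" and "open" are said of these compounds alone.

Of the compounds shown here, two sharing one core have been measured in an ADME assay on the whole organism (blood, Mus musculus, strain C57BL/6) for pharmacokinetics, read by HPLC, with a stated time of 4 h, at a dose of 2 mg/kg by the intraperitoneal route; a higher number here means more compound in the circulation at the dose given, a lower number less compound in the circulation. Compound 1 `CN1CCC2(CC1)CC(S(=O)(=O)c1c(Cl)ccc(NC(=O)Nc3cccc(F)c3Cl)c1O)C2` gives 1390 ng.h/mL in this assay, whereas compound 2 `CC(C)N1CCN(S(=O)(=O)c2c(Cl)ccc(NC(=O)Nc3cccc(F)c3Cl)c2O)CC1` gives 52.9 ng.h/mL. Among the measured compounds shown here, of the two numbers, compound 2 stands lowest, and the only step between measured compounds is a 26-fold lower number from compound 1 to compound 2 (1.42 log units; beyond the scatter), a change confined to the group on the sulfonyl sulfur. Compound 3 `CN1CC[C@H](S(=O)(=O)c2c(Cl)ccc(NC(=O)Nc3cccc(F)c3Cl)c2O)C1` is not yet measured; its change from compound 2 is 1-methylpyrrolidin-3-yl in place of 4-isopropylpiperazin-1-yl on a sulfonyl sulfur. That single measured step bears on the new compound only loosely, yet it shows that this position can move exposure a great deal. In build, compound 3 leans back toward compound 1, though with a smaller ring. A rise is expected because a 26-fold lower number from compound 1 to compound 2 (1.42 log units; beyond the scatter) was large, amounting to about a 5.7-fold higher number from compound 2 to compound 3 (0.75 log units; beyond the scatter). Compound 3 is estimated at 300 ng.h/mL, within a range from 80 ng.h/mL to 1200 ng.h/mL.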

Compound 3, area under the concentration-time curve: 432 ng.h/mL
The estimate for compound 3 lay 1.4-fold (0.16 log units) below the measured number; low and high end bracket the measured number.
By their numbers in this assay, from the lowest: compound 2; then compound 3; then compound 1.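

In this assay the step of an 8.2-fold higher number from compound 2 to compound 3 (0.91 log units; beyond the scatter) shows that a large gain at this position does not require the bulky two-ring group of compound 1, since 1-methylpyrrolidin-3-yl has fewer heavy atoms than 4-isopropylpiperazin-1-yl. Even so, the step of a 3.2-fold lower number from compound 1 to compound 3 (0.51 log units; beyond the scatter) leaves compound 3 well short of compound 1, so the group on the sulfonyl sulfur still matters beyond the scatter. No supporting measurement explains either difference.

The change from compound 2 to compound 3 alters ring size, the group on the ring nitrogen and the ring atom bonded to sulfur all at once, so the compounds shown cannot say which of these counts. As far as these compounds go, a 1-methylpiperidin-4-yl group or a 1-isopropylpyrrolidin-3-yl group would help separate them, and the mirror-image form of compound 3 also remains open.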